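A few compounds are considered here, and "the series" means these few. Any claim that something is new, unique, unknown or untested is made for them only; others in the source may bear on it.

Compound 1, `Nc1cc(N)c2nc(-c3ccccc3)c(Oc3ccc(Cl)c(Cl)c3)nc2c1`: 28200 nM
Compound 2, `CCOC(=O)[C@H](CCC(=O)O)NC(=O)c1ccc(CNc2nc3cc(N)cc(N)c3nc2-c2ccccc2)cc1`: 19500 nM
Compound 3, `Nc1cc(N)c2nc(-c3ccccc3)c(NCc3ccc(Cl)c(Cl)c3)nc2c1`: 4570 nM

All three compounds share one core and differ only in the group hung from it. In a functional assay on UACC-257 cells (Homo sapiens) for inhibition, read by sulforhodamine B assay, with a stated time of 48 h (on this read-out higher numbers stand for weaker inhibition of growth and lower numbers for stronger inhibition of growth), compound 3 gives 4570 nM, the lowest of the three numbers and therefore the strongest growth inhibition seen so far. Compound 2 gives 19500 nM and compound 1 gives 28200 nM, and both of these gaps to compound 3 lie beyond the usual scatter of the assay.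

The next compound, compound 4, has the structure `COc1ccc(CNc2nc3cc(N)cc(N)c3nc2-c2ccccc2)cc1OC`. Compared with compound 3 the change is 3,4-dimethoxyphenyl in place of 3,4-dichlorophenyl on a saturated chain carbon bound to a nitrogen on an aromatic ring. Going by the values given here, no pair of measured compounds shows this exact swap, so the size of the step can only be guessed from the spread of the three numbers known. A modest move toward weaker inhibition seems the most likely outcome, though a step that stays within the scatter cannot be excluded. Compound 4 is therefore expected to give about 9000 nM in this assay, within a range from 3000 nM to 30000 nM. The estimated step of a 2.0-fold higher number from compound 3 to compound 4 (0.29 log units; within the scatter) points toward weaker inhibition of growth.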

Compound 4, concentration for 50% growth inhibition: 12900 nM
Compound 4: the middle estimate sits 1.4-fold (0.16 log units) below what was measured; the range from low to high includes it.
By their numbers in this assay, from the lowest: compound 3; then compounds 4, 2 and 1 (each within the scatter of the next, the first and the last beyond it).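

In this assay, replacing 3,4-dichlorophenyl with 3,4-dimethoxyphenyl on a saturated chain carbon bound to a nitrogen on an aromatic ring gives a 2.8-fold higher number from compound 3 to compound 4 (0.45 log units; beyond the scatter), a modest move toward weaker inhibition of growth. Going by these compounds alone, this is the first direct comparison at this position, and it shows that the read-out responds to the groups carried on the phenyl ring even when the ring and its link to the shared core stay the same. Nothing measured here explains the reason for this step.

As far as these compounds go, both chlorines were exchanged for methoxy groups in one step, so it remains open whether one ring substituent alone accounts for the change. From the compounds shown here alone, how a plain phenyl, a single methoxy or a trifluoromethyl group would compare at this place also remains open.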